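Working notes: acetyl in place of 4-chlorophenyl

A few compounds are considered here, and "the series" means these few. Any claim that something is new, unique, unknown or untested is made for them only; others in the source may bear on it.

Measured in an ADME assay on MDBK cells (Bos taurus) for cytotoxicity, read by MTT assay, with a stated time of 96 h; a lower number here means that less compound is tolerated, a higher number that more compound is tolerated:
- compound 1 `FC(F)(F)c1cccc(NC(=S)Nc2ccc(Cl)cc2)c1` gives 17000 nM
- compound 2 `O=[N+]([O-])c1ccc(NC(=S)Nc2cccc(C(F)(F)F)c2)cc1` gives 10000 nM
- compound 3 `N#Cc1ccc(NC(=S)Nc2cccc(C(F)(F)F)c2)cc1` gives 10000 nM

Compound 1 stands within the scatter of both other compounds. Compound 4 `CC(=O)NC(=S)Nc1cccc(C(F)(F)F)c1` has acetyl in place of 4-chlorophenyl on an amide-type nitrogen and remains unmeasured. The measured steps only exchange chloro, nitro and cyano on an aromatic carbon: a 1.7-fold lower number from compound 1 to compound 2 (0.23 log units; within the scatter) then a 1.7-fold lower number from compound 1 to compound 3 (0.23 log units; within the scatter) and no change at the digits printed from compound 2 to compound 3 (within the scatter) are all small. None of them covers the loss of this ring, so they give only a weak guide. A moderate move toward a higher number in this assay is expected, with wide uncertainty. The estimated step is a 1.8-fold higher number from compound 1 to compound 4 (0.25 log units; within the scatter) for this change. Compound 4 is estimated at 30000 nM with an expected range of 9000 nM to 100000 nM in this read-out.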

Compound 4, half-maximal cytotoxic concentration: > 100000 nM
Compound 4: a limit, no number; the forecaster's own chance of this, stated with the estimate: 35%; middle value at least 3.3-fold (0.52 log units) away from the limit.
By their numbers in this assay, from the lowest: compounds 2, 3 and 1 (each within the scatter of the next). At a limit, above all of these: compound 4.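

In this assay, acetyl in place of 4-chlorophenyl on the amide-type nitrogen gives an at least 5.8-fold higher number from compound 1 to compound 4 (0.76 log units; beyond the scatter), the only step shown that lies beyond the scatter. Exchanges of chloro, nitro and cyano on the aromatic carbon all stayed within the scatter, so replacing the whole 4-chlorophenyl group reaches further than those exchanges did. The reading for compound 4 is a limit, not a number: the limit of > 100000 nM in this assay, at which 1 of the 4 values shown sits.

The compounds shown do not separate loss of the ring from gain of the acetyl. On these data alone, how a longer chain or an amine on the amide-type nitrogen would read in this assay remains open.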